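Chloro in Place of Methoxy: Expectation for Compound 4

A few compounds are considered here, and "the series" means these few. Any claim that something is new, unique, unknown or untested is made for them only; others in the source may bear on it.

Compound 1 `COc1ccccc1N1CCN(CCCn2nc(-n3cnc4ccccc43)ccc2=O)CC1`: 6.5 nM
Compound 2 `COc1ccccc1N1CCN(CCCCn2nc(-n3cnc4ccccc43)ccc2=O)CC1`: 1.1 nM
Compound 3 `COc1ccccc1N1CCN(CCCCCCn2nc(-n3cnc4ccccc43)ccc2=O)CC1`: 6.4 nM

These three compounds were measured in an assay on cell membranes from brain for binding affinity to Adrenergic receptor alpha-1 (Rattus norvegicus), read by radioligand binding; a lower number here means a stronger inhibitor, a higher number a weaker inhibitor. Compound 3 shows the second highest of the three numbers; its value lies within the scatter of compound 1, so the two cannot be told apart, while compound 2 gives a lower number, beyond the scatter. Compound 4 `O=c1ccc(-n2cnc3ccccc32)nn1CCCCCCN1CCN(c2ccccc2Cl)CC1` has not been measured. It differs from compound 3 in one place: chloro in place of methoxy on an aromatic carbon. For the measured compounds named here, no pair of measured compounds shows this change, so its effect here is unknown. A small step toward a higher number is expected, a 1.9-fold higher number from compound 3 to compound 4 (0.27 log units; within the scatter), though the outcome could also fall within the scatter. Compound 4 is therefore estimated at 12 nM in this assay, with a range from 3 nM to 50 nM.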

Compound 4, inhibition constant: 15.1 nM
Estimate against measurement, compound 4: 1.3-fold (0.10 log units) below; low and high end bracket the measured number.
By their numbers in this assay, from the lowest: compound 2; then compounds 3 and 1 (each within the scatter of the next); then compound 4.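

For the compounds shown here, compound 4 gives the first measured change at this position: in this assay, going from 2-methoxyphenyl to 2-chlorophenyl produces a 2.4-fold higher number from compound 3 to compound 4 (0.37 log units; beyond the scatter), a modest but real weakening. The binding number therefore responds to the group at this aromatic carbon, and on the longest chain shown, chloro does not match methoxy. Nothing available explains this step.

On these data alone, whether the same change would have a similar effect on the shorter chains of compound 1 and compound 2 remains open. So does the effect of fluoro, methyl or an amine at this position.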